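The source may hold more compounds than are shown below. What is called first, only, known or untested is meant among the compounds shown, and "the series" means these compounds.

Three measured compounds share a core that carries a guanidine-bearing chain and a trifluoromethylbenzyl amide, differing only in the aromatic group on one carbonyl carbon. In a functional assay on HEK293 cells for antagonist activity at melanin-concentrating hormone receptor 1 (Homo sapiens) (on this read-out higher numbers stand for weaker inhibition and lower numbers for stronger inhibition), compound 1 `N=C(N)NCCC[C@@H](NC(=O)c1cnc2ccccc2c1)C(=O)NCc1ccc(C(F)(F)F)cc1` gives 96 nM, compound 2 `N=C(N)NCCC[C@@H](NC(=O)c1ccc(F)c2ccccc12)C(=O)NCc1ccc(C(F)(F)F)cc1` gives 311 nM, and compound 3 `COc1cccc2cc(C(=O)N[C@H](CCCNC(=N)N)C(=O)NCc3ccc(C(F)(F)F)cc3)oc12` gives 622 nM, the highest of the three numbers. The steps were a 3.2-fold higher number from compound 1 to compound 2 (0.51 log units; beyond the scatter), a 6.5-fold higher number from compound 1 to compound 3 (0.81 log units; beyond the scatter) and a 2.0-fold higher number from compound 2 to compound 3 (0.30 log units; within the scatter).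

Compound 4 `N=C(N)NCCC[C@@H](NC(=O)c1ccc2ccccc2n1)C(=O)NCc1ccc(C(F)(F)F)cc1` differs from compound 3 by quinolin-2-yl in place of 7-methoxy-1-benzofuran-2-yl on a carbonyl carbon. The most telling step is the reverse direction of a 6.5-fold higher number from compound 1 to compound 3 (0.81 log units; beyond the scatter), since compound 1 also carries a quinolinyl group. A step of roughly that size downward, a 4.4-fold lower number from compound 3 to compound 4 (0.65 log units; beyond the scatter), is therefore expected. In this assay compound 4 is estimated at 140 nM, within 50 nM to 450 nM.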

Compound 4, half-maximal inhibitory concentration: 904 nM
For compound 4 the middle estimate is 6.5-fold (0.81 log units) below the measured one; the whole stated range lies below it.
By their numbers in this assay, from the lowest: compound 1; then compounds 2, 3 and 4 (each within the scatter of the next, the first and the last beyond it).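

Having a quinoline at this carbonyl carbon does not by itself give a low number: quinolin-2-yl in place of quinolin-3-yl brings a 9.4-fold higher number from compound 1 to compound 4 (0.97 log units; beyond the scatter), the largest step shown. Quinolin-2-yl also gives a 2.9-fold higher number from compound 2 to compound 4 (0.46 log units; beyond the scatter), whereas a 1.5-fold higher number from compound 3 to compound 4 (0.16 log units; within the scatter) leaves it indistinguishable from 7-methoxy-1-benzofuran-2-yl. Nothing available explains why these two quinolinyl groups differ.

As far as these compounds go, whether a plain phenyl group, or a quinolin-3-yl group also carrying a methoxy group, would lower the number further remains open.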